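Chlorophenyl in Place of Methylphenyl on the Nitrogen

A few compounds are considered here, and "the series" means these few. Any claim that something is new, unique, unknown or untested is made for them only; others in the source may bear on it.

Of the compounds shown here, two that share one core have been measured in an assay on isolated protein for inhibition of Polyunsaturated fatty acid 5-lipoxygenase (Homo sapiens), tested at 10 uM; on this read-out lower numbers stand for less inhibition and higher numbers for more inhibition at the one concentration tested (going by the name of the read-out). In this assay compound 1 `CCOC(=O)c1c(N2CCN(c3ccc(F)cc3)CC2)[nH]c2ccc(O)cc12` gives 81%. Compound 2 `CCOC(=O)c1c(Nc2ccc(C)cc2)[nH]c2ccc(O)cc12` gives 77% in this assay, a number that sits within the usual scatter of compound 1, so the two cannot be told apart on these measurements.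

Compound 3 `CCOC(=O)c1c(Nc2cccc(Cl)c2)[nH]c2ccc(O)cc12` has not yet been measured. It differs from compound 2 in one place: 3-chlorophenyl in place of 4-methylphenyl on a nitrogen on an aromatic ring. Within the data shown here, no measured pair shows a change of this kind, so there is no step to lean on. Both measured compounds sit high in this assay while carrying different groups on that nitrogen, which gives some reason to expect a small step from compound 2 to compound 3, a number 7 percentage points lower from compound 2 to compound 3 (within the scatter), hardly beyond the scatter. Compound 3 is therefore estimated at 70%, with a range from 45% to 90%.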

Compound 3, a percentage reported as inhibition, at one concentration (the size of the read-out at that concentration, not a potency): 97%
Compound 3: the middle estimate sits 27 percentage points below what was measured; the whole stated range lies below it.
By their numbers in this assay, from the lowest: compounds 2 and 1 (each within the scatter of the next); then compound 3.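

Replacing 4-methylphenyl with 3-chlorophenyl on this nitrogen gives a number 20 percentage points higher from compound 2 to compound 3 (beyond the scatter) in this assay, so the read-out does respond to the group at this position. The two groups have the same number of heavy atoms and neither carries a hydrogen-bond donor or acceptor, so these simple counts do not separate them, yet the read-out does. Nothing measured here explains the gain.

This swap changes both the substituent and its numbered place on the phenyl ring, so the compounds shown cannot say which of the two matters; 3-methylphenyl and 4-chlorophenyl would separate them. Also open, on these data alone, is how other groups at this position, such as 3-methoxyphenyl or 3-aminophenyl, would compare with 3-chlorophenyl.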